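The compounds below may be only part of what the source reports. "The series", "measured", "known", "first", "only" and "open" are said of these compounds alone.

Measured so far:
compound 1 `O=C(N[C@@H]1CCNC1)c1cc(-c2ccc(NS(=O)(=O)c3cccc(Cl)c3Cl)cc2)nc2[nH]ncc12` — < 1 nM
compound 2 `CNC(=O)c1cc(-c2ccc(NS(=O)(=O)c3cccc(Cl)c3Cl)cc2)nc2[nH]ncc12` — 4 nM

In an assay for inhibition of serine/threonine-protein kinase Sgk1 (Homo sapiens), with stated times of 30 min and 60 min, in the presence of a further agent that is not named here (a higher number here means a weaker inhibitor, a lower number a stronger inhibitor), compound 1 gives < 1 nM, a limit of the assay rather than a number. In this assay compound 2 gives 4 nM. Among the measured compounds shown here, the single measured step, an at least 4.0-fold higher number from compound 1 to compound 2 (0.60 log units; beyond the scatter), rests on the limit (the limit of < 1 nM in this assay, at which 1 of the 2 values shown sits), so only its minimum size is known. Compound 3 `CN1CCC(CNC(=O)c2cc(-c3ccc(NS(=O)(=O)c4cccc(Cl)c4Cl)cc3)nc3[nH]ncc23)C1` differs from compound 1 by (1-methylpyrrolidin-3-yl)methyl in place of pyrrolidin-3-yl on an amide-type nitrogen. The five-membered ring is kept here, unlike in compound 2, so a step of that size is not anticipated. Compound 3 is expected to give 1.5 nM (range 0.5 nM to 5 nM), meaning an expected step of an at least 1.5-fold higher number from compound 1 to compound 3 (0.17 log units; that floor lies within the scatter).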

Compound 3, half-maximal inhibitory concentration: 14 nM
Estimate against measurement, compound 3: 9.3-fold (0.97 log units) below; measured number above the stated range.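

In this assay, (1-methylpyrrolidin-3-yl)methyl in place of pyrrolidin-3-yl gives an at least 14-fold higher number from compound 1 to compound 3 (1.14 log units; beyond the scatter), so keeping the five-membered ring does not by itself preserve the low number. Compound 1 stands at a limit, so only the minimum size of this step is known: the limit of < 1 nM in this assay, at which 1 of the 3 values shown sits.

The same group also compares poorly with the small methyl amide, with a 3.5-fold higher number from compound 2 to compound 3 (0.54 log units; beyond the scatter). Still open, from the compounds shown here alone, is whether the added ring methyl or the added chain carbon carries the loss. (Pyrrolidin-3-yl)methyl and 1-methylpyrrolidin-3-yl on the amide-type nitrogen would separate the two.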